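The source may hold more compounds than are shown below. What is called first, only, known or untested is meant among the compounds shown, and "the series" means these compounds.

Measured so far:
- Compound 1 `CC(C)=CCc1cc(C(=O)Nc2cc3ccc(OCCCN4CCCC4)c(C)c3oc2=O)ccc1O`: 720 nM
- Compound 2 `CC(C)=CCc1cc(C(=O)Nc2cc3ccc(OCCCN(C(C)C)C(C)C)c(C)c3oc2=O)ccc1O`: 1600 nM

In a functional assay on SK-BR-3 cells (Homo sapiens) for antiproliferative activity (on this read-out higher numbers stand for weaker inhibition and lower numbers for stronger inhibition), compound 2 gives the higher of the two numbers, 1600 nM. Compound 3 `COC(=O)CNCCCOc1ccc2cc(NC(=O)c3ccc(O)c(CC=C(C)C)c3)c(=O)oc2c1C` is not yet measured. It carries ((methoxycarbonyl)methyl)amino in place of diisopropylamino on a saturated chain carbon, three bonds along the chain from an oxygen on an aromatic ring.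

Within the data shown here, only one measured step bears on this place: a 2.2-fold higher number from compound 1 to compound 2 (0.35 log units; beyond the scatter), a modest one. Neither measured compound carries the entering group, so a similarly modest change of uncertain direction is expected in this assay. The estimated step is a 1.1-fold lower number from compound 2 to compound 3 (0.06 log units; within the scatter). For compound 3 the expected value is 1400 nM, with an estimated range of 450 nM to 4500 nM.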

Compound 3, half-maximal inhibitory concentration: 1060 nM
Compound 3: the middle estimate sits 1.3-fold (0.12 log units) above what was measured; the range from low to high includes it.
By their numbers in this assay, from the lowest: compounds 1, 3 and 2 (each within the scatter of the next, the first and the last beyond it).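

In this assay, putting ((methoxycarbonyl)methyl)amino in place of diisopropylamino gives a 1.5-fold lower number from compound 2 to compound 3 (0.18 log units; within the scatter) and putting it in place of pyrrolidin-1-yl gives a 1.5-fold higher number from compound 1 to compound 3 (0.17 log units; within the scatter). Compound 3 thus shows that this group, with its hydrogen-bond donor and three acceptors, stays within the scatter of both earlier amino groups on the same propyl chain. No evidence at hand accounts for these steps. Still open, going by these compounds, is whether a carboxylic acid in place of the methyl ester would stay within that scatter. On these data alone, a morpholine on the same chain remains equally open.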